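This account rests on a few compounds, and the source may have more. Where it says the series, first, only, none or still open, it means among the compounds named here.

Compound 1 `COc1cc(OC)c(C(=O)/C=C/c2ccccc2Cl)c(O)c1CN(C)CC(=O)O` gives 80300 nM in a functional assay on HL-60 cells (Homo sapiens) for antiproliferative activity, with a stated time of 72 h (on this read-out lower numbers stand for stronger inhibition and higher numbers for weaker inhibition), and compound 2 `COc1cc(O)c2c(=O)cc(-c3ccccc3Cl)oc2c1CN1CCCCC1` gives 48100 nM in the same read-out, so the two stand within the usual scatter of each other. Compound 3 `COc1cc(OC)c(C(=O)/C=C/c2ccccc2Cl)c(O)c1CN(C)CCCN(C)C` differs from compound 1 in one place: 2-(dimethylamino)ethyl in place of carboxy on a saturated chain carbon bound to an amine nitrogen. Among the measured compounds shown here, no measured pair shows this change, so the expectation in this assay is a judgement: a step to a lower number, beyond the scatter. The estimate for compound 3 is 15000 nM with an expected range from 3000 nM to 60000 nM in this series. That estimate means a 5.4-fold lower number from compound 1 to compound 3 (0.73 log units; beyond the scatter) as the expected step.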

Compound 3, half-maximal inhibitory concentration: 11400 nM
The estimate for compound 3 lay 1.3-fold (0.12 log units) above the measured number; measured number inside the range.
By their numbers in this assay, from the lowest: compound 3; then compounds 2 and 1 (each within the scatter of the next).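

In this assay, among the compounds shown here, the end of the side chain matters at this place, on a saturated chain carbon bound to an amine nitrogen: 2-(dimethylamino)ethyl in place of carboxy gives a 7.0-fold lower number from compound 1 to compound 3 (0.85 log units; beyond the scatter), the first single-place step. The change also removes the hydrogen-bond donor of carboxy and brings in nitrogen and more heavy atoms, so several features move together. Nothing at hand bears on why the number falls.

Which of these features carries the step stays open. A methyl ester, a primary amide or a primary amine at this place could help separate them.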